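Solubility notes on a pyridin-3-yl analogue

The source may report more compounds than this note shows. Statements on the series, on what has been measured and on what is new or still open speak of the compounds shown alone.

Compound 1 `CCOC(=O)C1=C(C)N/C(=C/c2cc(C)n(-c3ccc(CN(C)C)cc3)c2C)C1=O` stands highest of the three measured compounds in a physicochemical assay for solubility, read by nephelometry, measured as kinetic solubility, at pH 2.0 (a lower number here means a less soluble compound, a higher number a more soluble compound), at 50 ug/mL. Compound 2 `CCOC(=O)C1=C(C)N/C(=C/c2cc(C)n(-c3ccc(Cl)cc3)c2C)C1=O` gives 1.6 ug/mL and compound 3 `CCOC(=O)C1=C(C)N/C(=C/c2cc(C)n(-c3ccc(N(C)C)cc3)c2C)C1=O` gives 12.5 ug/mL; the steps are a 31-fold lower number from compound 1 to compound 2 (1.49 log units; beyond the scatter), a 4.0-fold lower number from compound 1 to compound 3 (0.60 log units; beyond the scatter) and a 7.8-fold higher number from compound 2 to compound 3 (0.89 log units; beyond the scatter). Compound 4 `CCOC(=O)C1=C(C)N/C(=C/c2cc(C)n(-c3cccnc3)c2C)C1=O` differs from compound 1 by pyridin-3-yl in place of 4-((dimethylamino)methyl)phenyl on an aromatic nitrogen. Both measured steps from compound 1 remove the (dimethylamino)methyl group and both lower the number, the chloro step large and the dimethylamino step modest. The pyridin-3-yl change removes the same group while keeping one hydrogen-bond acceptor, so for compound 4 the expected step is modest and downward, a 3.3-fold lower number from compound 1 to compound 4 (0.52 log units; beyond the scatter). Compound 4 is therefore estimated at 15 ug/mL, between 4 ug/mL and 50 ug/mL.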

Compound 4, solubility: > 50 ug/mL
Compound 4: only a limit was reported (the forecaster's own chance of this, stated with the estimate: 5%); middle value at least 3.3-fold (0.52 log units) away from the limit.
By their numbers in this assay, from the lowest: compound 2; then compound 3; then compound 1.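

Compound 4 gives > 50 ug/mL in this assay, and this is a limit of the assay, not a number. Pyridin-3-yl on the aromatic nitrogen stands clear of both other groups without a (dimethylamino)methyl group, with an at least 4.0-fold higher number from compound 3 to compound 4 (0.60 log units; beyond the scatter) and an at least 31-fold higher number from compound 2 to compound 4 (1.49 log units; beyond the scatter). The remaining step is a number no lower from compound 1 to compound 4 (the limit leaves the size open) and its size cannot be read, but here, unlike in compound 2 and compound 3, losing the (dimethylamino)methyl group gives no lower number.

As far as these compounds go, how far compound 4 lies beyond compound 1 stays open. Also open, from the compounds shown here alone, is how a plain phenyl or a pyridin-4-yl group on the same nitrogen would compare with pyridin-3-yl.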